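Ring-nitrogen substituent changes on a shared acid core

This account rests on a few compounds, and the source may have more. Where it says the series, first, only, none or still open, it means among the compounds named here.

Measured in a functional assay on HEK293 cells for agonist activity at Free fatty acid receptor 1 (Homo sapiens), read by fluorescence and calcium flux; a higher number here means that more compound is needed for the effect, a lower number that less compound is needed:
Compound 1 `CC#CC(CC(=O)O)c1ccc(OCc2ccc(C(=O)N3CCN(Cc4ccccc4)CC3)s2)cc1` — 155 nM
Compound 2 `CC#CC(CC(=O)O)c1ccc(OCc2ccc(C(=O)N3CCN(c4ccccn4)CC3)s2)cc1` — 138 nM
Compound 3 `CC#CC(CC(=O)O)c1ccc(OCc2ccc(C(=O)N3CCN(c4cccc(F)c4)CC3)s2)cc1` — 97 nM

Compound 1 carries the largest of the three numbers, but both steps away from it stay within the scatter: a 1.1-fold lower number from compound 1 to compound 2 (0.05 log units; within the scatter) and a 1.6-fold lower number from compound 1 to compound 3 (0.20 log units; within the scatter). The two aryl variants are likewise indistinguishable from each other, a 1.4-fold lower number from compound 2 to compound 3 (0.15 log units; within the scatter). On these three numbers nothing separates benzyl from a directly attached six-membered aromatic ring on the ring nitrogen.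

Compound 4 `CC#CC(CC(=O)O)c1ccc(OCc2ccc(C(=O)N3CCN(c4ccccc4[N+](=O)[O-])CC3)s2)cc1` is the next member. Against compound 1 the single change is 2-nitrophenyl in place of benzyl on an amine nitrogen in a ring. Among the compounds with values here, the steps that bear on it are those from compound 1 to compound 2 and to compound 3, each an exchange of benzyl for a ring carrying a small substituent or a ring nitrogen, and each within the scatter. A further substituted aryl on the same nitrogen is therefore expected to behave alike, with no step beyond the scatter in this assay in either direction. Compound 4 is estimated at 125 nM, range 55 nM to 300 nM, which means an expected step of a 1.2-fold lower number from compound 1 to compound 4 (0.09 log units; within the scatter).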

Compound 4, half-maximal effective concentration: 94 nM
Estimate against measurement, compound 4: 1.3-fold (0.12 log units) above; low and high end bracket the measured number.
By their numbers in this assay, from the lowest: compounds 4, 3, 2 and 1 (each within the scatter of the next).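

In this assay, the ring nitrogen now carries 2-nitrophenyl, which has more heavy atoms than benzyl and a double bond outside aromatic rings, yet all three new steps stay within the scatter: a 1.6-fold lower number from compound 1 to compound 4 (0.22 log units; within the scatter), a 1.5-fold lower number from compound 2 to compound 4 (0.17 log units; within the scatter) and a 1.0-fold lower number from compound 3 to compound 4 (0.01 log units; within the scatter). Within the data shown here, the flat picture from the earlier compounds therefore extends to a substituted aryl with hydrogen-bond acceptors, and all four groups at this position remain indistinguishable. No data are available that bear on the reason for this result.

On these data alone, whether the flat picture holds for a simple alkyl chain, an acetyl group or an unsubstituted phenyl on the same nitrogen remains open. Also open, as far as these compounds go, is whether moving the nitro group to another ring position, or replacing it with an amine, would give a step beyond the scatter.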